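A Methyl Step Tried on a Second Core

This account rests on a few compounds, and the source may have more. Where it says the series, first, only, none or still open, it means among the compounds named here.

Measured so far:
Compound 1, `CC/N=C(/NC#N)NCCCn1nc(-c2ccccc2)ccc1=O`, gives 78.3 mg/kg in a functional assay on the whole organism (stomach) with Rattus norvegicus as the target; a lower number here means that less compound is needed, a higher number that more compound is needed for the effect.
Compound 2, `CCC/N=C(/NC#N)NCCCn1nc(-c2ccccc2)ccc1=O`, gives 100 mg/kg in this assay.
Compound 3, `C/N=C(\S)NCCCCn1nc(-c2ccccc2)ccc1=O`, gives 28.9 mg/kg in this assay.

Compounds 1 and 2 share one core and differ only by methyl in place of hydrogen on a saturated chain carbon, two bonds along the chain from a double-bonded nitrogen. That change made a 1.3-fold higher number from compound 1 to compound 2 (0.11 log units; within the scatter), so the two values cannot be told apart with confidence.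

Compound 3 carries a different core, and the difference between the two cores is a group of 6 heavy atoms (3 carbon, 2 nitrogen, 1 sulfur; no ring) in place of a group of 8 heavy atoms (4 carbon, 4 nitrogen; no ring), on a saturated chain carbon, three bonds along the chain from an aromatic nitrogen. This change made a 2.7-fold lower number from compound 1 to compound 3 (0.43 log units; beyond the scatter), and compound 3 gives the lowest number of the three.

Compound 4, `CC/N=C(\S)NCCCCn1nc(-c2ccccc2)ccc1=O`, is not yet measured. It differs from compound 3 by methyl in place of hydrogen on a saturated chain carbon bound to a double-bonded nitrogen. Among the measured compounds shown here, this is the same kind of change as the one from compound 1 to compound 2, but not the same: in compound 4 the methyl enters on a saturated chain carbon bound to a double-bonded nitrogen, whereas in compound 2 it entered on a saturated chain carbon two bonds along the chain from a double-bonded nitrogen, and the core is the one of compound 3 rather than that of compound 1.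

For the measured compounds named here, only one earlier example of this kind of change exists here, and it lies within the scatter. On that basis the step from compound 3 to compound 4 is expected to be a 1.1-fold higher number from compound 3 to compound 4 (0.06 log units; within the scatter), an expectation that rests on compound 1 to compound 2 giving a 1.3-fold higher number from compound 1 to compound 2 (0.11 log units; within the scatter). Compound 4 is therefore estimated at 33 mg/kg in this assay, with the expected range running from 17 mg/kg to 65 mg/kg.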

Compound 4, dose for half-maximal effect: 37.2 mg/kg
Compound 4: middle estimate off by 1.1-fold (0.05 log units), on the low side; measured number inside the range.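

In this assay, the methyl step on the core of compound 3 gave a 1.3-fold higher number from compound 3 to compound 4 (0.11 log units; within the scatter), and it can be set directly beside the earlier step on the core of compound 1: the same change on two cores in this assay, a 1.3-fold higher number (0.11 log units; within the scatter) from compound 1 to compound 2 and a 1.3-fold higher number (0.11 log units; within the scatter) from compound 3 to compound 4, 1.0-fold (0.00 log units) apart, within the scatter of two such steps. This shows that the change behaved alike on these two cores, with a step too small to separate from the scatter on either one, even though the methyl enters at a different place on the chain in each case. It does not show that the methyl has any real effect that carries over, since two steps inside the scatter can agree by chance, and the only clear gap lies in the exchange of the larger group, which gave a 2.1-fold lower number from compound 1 to compound 4 (0.32 log units; beyond the scatter), a modest step beyond the scatter.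

The compounds shown leave open whether a longer chain such as butyl, or a ring such as cyclopropyl, in place of the methyl or ethyl on the core of compound 3 would produce a step beyond the scatter. They also leave open whether the same methyl step would stay this small on a third core.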